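The compounds below may be only part of what the source reports. "The series", "measured", "known", "first", "only" and "open" are said of these compounds alone.

Two compounds of this series share one core and differ only in the group carried on an aromatic carbon of a five-membered aromatic ring with 2 nitrogen. Compound 1, `COc1cc(-c2ccnc3cc(-c4cn(CO)c5ccccc45)nn23)cc(OC)c1OC`, is the stronger of the pair in a functional assay on HCT-116 cells (Homo sapiens) for inhibition, read by CCK-8 assay, with a stated time of 48 h (on this read-out lower numbers stand for stronger inhibition and higher numbers for weaker inhibition), with a value of 128 nM. Compound 2, `COc1cc(-c2ccnc3cc(-c4ccccc4)nn23)cc(OC)c1OC`, gives in this assay a value of 3880 nM, the highest of the two numbers recorded and a step beyond the scatter away from compound 1. Compound 3, `COc1cc(-c2ccnc3cc(-c4ccc5cnn(C)c5c4)nn23)cc(OC)c1OC`, is not yet measured; it carries 1-methyl-1H-indazol-6-yl in place of phenyl on an aromatic carbon. Because compound 1 with its larger fused group reaches 128 nM, a lower number than compound 2 is expected for compound 3, though a step as large as that between compound 2 and compound 1 is not assumed. The step from compound 2 to compound 3 is expected to be an 8.6-fold lower number from compound 2 to compound 3 (0.94 log units; beyond the scatter). Compound 3 is estimated at 450 nM, within a range of 150 nM to 1500 nM.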

Compound 3, half-maximal inhibitory concentration: 2440 nM
For compound 3 the middle estimate is 5.4-fold (0.73 log units) below the measured one, outside the stated range (above it).
By their numbers in this assay, from the lowest: compound 1; then compounds 3 and 2 (each within the scatter of the next).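

In this assay, putting 1-methyl-1H-indazol-6-yl in place of phenyl on this aromatic carbon gives a 1.6-fold lower number from compound 2 to compound 3 (0.20 log units; within the scatter), so this change leaves compound 2 and compound 3 indistinguishable in this read-out. A fused two-ring group at this place is thus not enough on its own to reach the value of compound 1, 128 nM, and the two hydrogen-bond acceptors counted in the new group bring no step beyond the scatter. No available evidence bears on why this exchange leaves the value within the scatter.

The group of compound 1 differs from that of compound 3 as a whole, so the shown compounds do not separate which of its parts matters. Also open, on these data alone, is how an amine or a carboxylic acid on the phenyl ring of compound 2 would read in this assay.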